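Rearranging the Chain on the Ring Nitrogen

This account rests on a few compounds, and the source may have more. Where it says the series, first, only, none or still open, it means among the compounds named here.

Three compounds have been measured in an assay on Prostate gland for inhibition of steroid 5-alpha-reductase (Rattus norvegicus); a higher number here means a weaker inhibitor, a lower number a stronger inhibitor:

compound 1, `C/C(=C\C(=O)Nc1ccccc1OCCCC(=O)O)c1ccc2c(ccn2C)c1`, gives 780 nM
compound 2, `CCCn1ccc2cc(/C(C)=C/C(=O)Nc3ccccc3OCCCC(=O)O)ccc21`, gives 190 nM
compound 3, `CCCCCCCn1ccc2cc(/C(C)=C/C(=O)Nc3ccccc3OCCCC(=O)O)ccc21`, gives 120 nM

Compound 3 has the lowest of the three numbers. Its nearest neighbour is compound 2, with a 1.6-fold lower number from compound 2 to compound 3 (0.20 log units; within the scatter), a gap within the scatter, so the two cannot be ranked. Its furthest is compound 1, with a 6.5-fold lower number from compound 1 to compound 3 (0.81 log units; beyond the scatter).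

Compound 4, `CCCC(C(C)C)n1ccc2cc(/C(C)=C/C(=O)Nc3ccccc3OCCCC(=O)O)ccc21`, carries 1-isopropylbutyl in place of heptyl on an aromatic nitrogen; the two compounds have the same atoms, joined differently.

Among the measured compounds shown here, the steps that bear on this are a 4.1-fold lower number from compound 1 to compound 2 (0.61 log units; beyond the scatter) and a 6.5-fold lower number from compound 1 to compound 3 (0.81 log units; beyond the scatter), both modest, and a 1.6-fold lower number from compound 2 to compound 3 (0.20 log units; within the scatter), within the scatter: lengthening the chain on the aromatic nitrogen lowers the number, but once a few carbons are present further length adds little. For the measured compounds named here, no measured step changes how a chain of fixed size is joined, so there is no evidence for a shift either way.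

For compound 4 the step of a 1.3-fold higher number from compound 3 to compound 4 (0.10 log units; within the scatter) is therefore expected to stay within the scatter, and the estimate for compound 4 is 150 nM, with a range from 60 nM to 400 nM.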

Compound 4, half-maximal inhibitory concentration: 7.2 nM
For compound 4 the middle estimate is 21-fold (1.32 log units) above the measured one, and the stated range ends above it.
By their numbers in this assay, from the lowest: compound 4; then compounds 3 and 2 (each within the scatter of the next); then compound 1.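

On the aromatic nitrogen, how the chain is joined matters far more than the earlier compounds could show: with the same atoms, 1-isopropylbutyl in place of heptyl gives a 17-fold lower number from compound 3 to compound 4 (1.22 log units; beyond the scatter) in this assay and no size effect can account for that step. The new group also stands well apart from the shorter chains, with a 26-fold lower number from compound 2 to compound 4 (1.42 log units; beyond the scatter) when it replaces propyl and a 110-fold lower number from compound 1 to compound 4 (2.03 log units; beyond the scatter) when it replaces methyl, whereas the step from propyl to heptyl stayed within the scatter. No evidence is available on why this rearrangement of the chain has such a large effect.

The compounds shown leave open whether a smaller branched group such as isopropyl, or a ring such as cyclohexyl, would match 1-isopropylbutyl. They also leave open whether the isopropyl branch itself is needed, which a group such as 1-propylbutyl could test.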